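The source may hold more compounds than are shown below. What is called first, only, known or untested is meant among the compounds shown, and "the series" means these compounds.

Compound 1 `C=Cn1c2ccc([N+](=O)[O-])cc2c(=O)n1Cc1ccccc1` is tested in an ADME assay on L929 cells (Mus musculus) for cytotoxicity, read by resazurin assay, with a stated time of 48 h (a lower number here means that less compound is tolerated, a higher number that more compound is tolerated), where compound 1 gives 160000 nM, the lowest of the two plain numbers. Compound 2 `C#CCn1c2ccc([N+](=O)[O-])cc2c(=O)n1Cc1ccccc1` gives 195000 nM in this assay, so the step of a 1.2-fold higher number from compound 1 to compound 2 (0.09 log units; within the scatter) is small. Compound 3 `NC(=O)CCCn1c2ccc([N+](=O)[O-])cc2c(=O)n1Cc1ccccc1` reaches only a limit of this assay, > 256000 nM, which is also the most that the assay reports, (the limit of > 256000 nM in this assay, at which 1 of the 3 values shown sits).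

Compound 4 `O=C(c1ccccc1)n1c2ccc([N+](=O)[O-])cc2c(=O)n1Cc1ccccc1` differs from compound 1 at one spot: benzoyl in place of vinyl on an aromatic nitrogen. The measured steps that start from compound 1, a 1.2-fold higher number from compound 1 to compound 2 (0.09 log units; within the scatter) and an at least 1.6-fold higher number from compound 1 to compound 3 (0.20 log units; that floor lies within the scatter), all stay within the scatter, so no change beyond the scatter is expected for the exchange of vinyl for benzoyl. Compound 4 is therefore estimated at 190000 nM, between 90000 nM and 400000 nM, a step of a 1.2-fold higher number from compound 1 to compound 4 (0.07 log units; within the scatter).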

Compound 4, concentration lethal to 50% of the cells: 146000 nM
Compound 4: middle estimate off by 1.3-fold (0.11 log units), on the high side, within the range that was stated.
By their numbers in this assay, from the lowest: compounds 4, 1 and 2 (each within the scatter of the next). At a limit, above all of these: compound 3.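

Benzoyl puts eight heavy atoms, including an aromatic ring and a hydrogen-bond acceptor, on the aromatic nitrogen where vinyl had two, yet this assay shows a 1.1-fold lower number from compound 1 to compound 4 (0.04 log units; within the scatter) and a 1.3-fold lower number from compound 2 to compound 4 (0.13 log units; within the scatter). A group carrying an aromatic ring at this position therefore stays within the scatter of the smaller groups. The remaining step, an at least 1.7-fold lower number from compound 3 to compound 4 (0.24 log units; that floor lies within the scatter), is only a floor, as one of its two values is a limit: the limit of > 256000 nM in this assay, at which 1 of the 4 values shown sits.

On these data alone, whether an amine or a carboxylic acid on this nitrogen would move the number beyond the scatter stays open.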